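Methyl added to the saturated ring: compound 2 to compound 4

The compounds below may be only part of what the source reports. "The series", "measured", "known", "first", "only" and "open" are said of these compounds alone.

Measured so far, all in a functional assay on HeLa cells (Homo sapiens) for inhibition, read by MTT assay, with a stated time of 24 h; on this read-out higher numbers stand for weaker inhibition and lower numbers for stronger inhibition:
compound 1 `CO/N=C1\C[C@@H](c2cccc(F)c2)N[C@@H](c2cccc(F)c2)[C@@H]1C` gives 38400 nM in this assay;
compound 2 `CO/N=C1\C[C@@H](c2ccc(OC)cc2)N[C@@H](c2ccc(OC)cc2)[C@@H]1C` gives 154000 nM in this assay;
compound 3 `CO/N=C1\C[C@@H](c2ccccc2)N[C@@H](c2ccccc2)[C@@H]1C(C)C` gives 49500 nM in this assay.

Compound 2 stands at the highest number of the three, that is, the weakest inhibition shown in this assay. Its nearest neighbour is compound 3, whose number is lower by a gap beyond the usual scatter; the furthest is compound 1, whose number is lower by a gap that is also beyond the scatter. Among the measured compounds shown here, compound 1 and compound 3 each differ from compound 2 in more than one place, so the set contains no single-change step against which a new change can be read.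

Compound 4 `CO/N=C1/[C@@H](C)[C@H](c2ccc(OC)cc2)N[C@H](c2ccc(OC)cc2)[C@H]1C` differs from compound 2 by methyl in place of hydrogen on a saturated ring carbon. Nothing in the measured set shows what this change does on this core. For the measured compounds named here, with compound 2 already at the weak end, and no comparable step to draw on, the expected step is no more than the scatter, with no preferred direction; the estimate taken here is a 1.2-fold lower number from compound 2 to compound 4 (0.07 log units; within the scatter). On that basis compound 4 is expected to give about 130000 nM in this assay, within a range of 50000 nM to 350000 nM.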

Compound 4, half-maximal inhibitory concentration: 93900 nM
For compound 4 the middle estimate is 1.4-fold (0.14 log units) above the measured one, and the stated range covers the measured number.
By their numbers in this assay, from the lowest: compounds 1, 3, 4 and 2 (each within the scatter of the next, the first and the last beyond it).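

In this assay, among the compounds shown here, methyl in place of hydrogen on the saturated ring carbon gives a 1.6-fold lower number from compound 2 to compound 4 (0.21 log units; within the scatter); this is the first single-change step, and it leaves compound 2 and compound 4 indistinguishable on this read-out. This position, next to the ring atom that bears a 4-methoxyphenyl group and two ring bonds from the ring nitrogen, therefore accepts one added methyl without a readable shift in this assay, though that reading rests on this single pair, whose members both carry the 4-methoxyphenyl groups. The data offer no measured basis for explaining this outcome.

As far as these compounds go, whether the same position stays as silent with a longer chain such as ethyl or propyl, or with a hydroxyl, an amine or a carboxylic acid, remains open. Also open, from the compounds shown here alone, is whether methyl at this carbon would give a similar step on the core of compound 1, which carries 3-fluorophenyl groups in place of the 4-methoxyphenyl groups and has a value of 38400 nM.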